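The source may hold more compounds than are shown below. What is called first, only, known or untested is meant among the compounds shown, and "the series" means these compounds.

Measured so far in an ADME assay on Raji cells (Homo sapiens) for cytotoxicity, read by luminescence, with a stated time of 72 h (a higher number here means that more compound is needed for the effect, a lower number that less compound is needed), each value a limit:
- Compound 1 `CCOC(=O)c1c(-c2ccccc2)[nH]c2cc(OC)ccc2c1=O` gives > 21500 nM as a limit
- Compound 2 `CCCOc1cccc(-c2[nH]c3cc(OC)ccc3c(=O)c2C(=O)OCC)c1` gives > 21500 nM as a limit
- Compound 3 `CCOC(=O)c1c(-c2cccc([N+](=O)[O-])c2)[nH]c2cc(OC)ccc2c1=O` gives > 21500 nM as a limit

Compound 3 stands at > 21500 nM as a limit and not as a number. The whole set stands the same way (the limit of > 21500 nM in this assay, at which 3 of the 3 values shown sit).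

The unmeasured compound 4 `CCOC(=O)c1c(-c2cccc(O)c2)[nH]c2cc(OC)ccc2c1=O` carries hydroxy in place of nitro on an aromatic carbon, the 3-nitrophenyl to 3-hydroxyphenyl change (hydroxy in place of nitro on an aromatic carbon). For the measured compounds named here, no measured compound carries hydroxy.

The steps that bear most directly on this change are a step that the two limits leave unreadable from compound 1 to compound 3 and a step that the two limits leave unreadable from compound 2 to compound 3 in the notes on the nitro group. The propoxy change adds a step that the two limits leave unreadable from compound 1 to compound 2 to the picture. None of these has a size that can be carried over.

With a step that the two limits leave unreadable from compound 1 to compound 3 as the closest guide, no step beyond the usual scatter is expected in this assay in either direction, and another limit is the likeliest report. The expected change is a step that the limit leaves unreadable from compound 3 to compound 4 as an estimate only. For compound 4 the estimate is 30000 nM with an expected range from 12000 nM to 60000 nM in this read-out.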

Compound 4, half-maximal effective concentration: > 21500 nM
Compound 4 gave a limit, no number; the forecaster's own chance of this, stated with the estimate: 85%; the middle value lies beyond the limit too.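

Compound 4 is reported only as a limit, so its steps to compound 1, compound 2 and compound 3 cannot be read, and the size of the hydroxy for nitro change stays unknown: the limit of > 21500 nM in this assay, at which 4 of the 4 values shown sit.

The compounds shown leave open whether hydroxy, nitro or propoxy shifts the read-out in this assay at all, and what value any of these compounds would give.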